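A few compounds are considered here, and "the series" means these few. Any claim that something is new, unique, unknown or untested is made for them only; others in the source may bear on it.

Measured in a functional assay on MDA-MB-231 cells (Homo sapiens) for cytotoxicity, read by MTT assay, with a stated time of 72 h; a lower number here means a stronger inhibitor, a higher number a weaker inhibitor:
- compound 1 `CN(C)Cc1ccc2nc(NC(=O)N/N=C/c3cn(Cc4ccccc4Cl)c4ccccc34)sc2c1`: 1180 nM
- compound 2 `CN(C)Cc1ccc2nc(NC(=O)N/N=C/c3cn(Cc4ccc(C(C)(C)C)cc4)c4ccccc34)sc2c1`: 2230 nM
- compound 3 `CN(C)Cc1ccc2nc(NC(=O)N/N=C/c3c[nH]c4ccccc34)sc2c1`: 1190 nM

All three values lie within the scatter of one another, so compound 3, at 1190 nM, cannot be ranked against the other two. Compound 4 `CN(C)Cc1ccc2nc(NC(=O)N/N=C/c3cn(Cc4ccccc4)c4ccccc34)sc2c1` has benzyl in place of hydrogen on an aromatic nitrogen.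

Going by the values given here, two measured steps bear most directly on this change, running from a substituted benzyl to hydrogen at the same nitrogen: a 1.0-fold higher number from compound 1 to compound 3 (0.00 log units; within the scatter) for 2-chlorobenzyl and a 1.9-fold lower number from compound 2 to compound 3 (0.27 log units; within the scatter) for 4-(tert-butyl)benzyl. Both lie within the scatter. The two substituted benzyl compounds also stay within it, at a 1.9-fold higher number from compound 1 to compound 2 (0.28 log units; within the scatter). Compound 4 itself carries neither substituent, so the comparison is indirect, but no step beyond the scatter is expected in this assay, and no direction can be assigned.

The expected step is a 1.2-fold higher number from compound 3 to compound 4 (0.07 log units; within the scatter). For compound 4 the estimated value is 1400 nM, with an expected range of 750 nM to 2600 nM.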

Compound 4, half-maximal inhibitory concentration: 1340 nM
Compound 4: middle estimate off by 1.0-fold (0.02 log units), on the high side; measured number inside the range.
By their numbers in this assay, from the lowest: compounds 1, 3, 4 and 2 (each within the scatter of the next).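

In this assay, benzyl in place of hydrogen on the aromatic nitrogen (a 1.1-fold higher number from compound 3 to compound 4 (0.05 log units; within the scatter)) stays within the scatter, so the unsubstituted benzyl cannot be told apart from the free nitrogen. The two substituted benzyl compounds also cannot be separated from the unsubstituted one: hydrogen in place of chloro on an aromatic carbon (a 1.1-fold higher number from compound 1 to compound 4 (0.06 log units; within the scatter)) and hydrogen in place of tert-butyl on an aromatic carbon (a 1.7-fold lower number from compound 2 to compound 4 (0.22 log units; within the scatter)) both lie within the scatter. No supporting data are available to explain this flat picture.

Still open, as far as these compounds go, is whether a group of a different kind on this nitrogen, such as a longer chain ending in an amine or a carboxylic acid, would give a step beyond the scatter. Also open, from the compounds shown here alone, is whether this flat reading extends beyond this assay.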